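This account rests on a few compounds, and the source may have more. Where it says the series, first, only, none or still open, it means among the compounds named here.

Of the compounds shown here, three built on the same core have been tested in a functional assay on PC-3 cells (Homo sapiens) for antiproliferative activity, read by MTT assay, with a stated time of 48 h; on this read-out lower numbers stand for stronger inhibition and higher numbers for weaker inhibition. Compound 1 `COc1cc(/C=C/C(C)=O)ccc1OCc1cn(-c2ccc(C)cc2)nn1` gives 58100 nM in this assay. Compound 2 `CCOC(=O)c1ccc(-n2cc(COc3ccc(/C=C/C(C)=O)cc3OC)nn2)cc1` gives 59200 nM, and compound 3 `COc1cc(/C=C/C(C)=O)ccc1OCc1cn(-c2ccccc2Cl)nn1` gives 48000 nM. The number for compound 3 is the lowest of the three, but its gaps to compound 1 and compound 2 are both within the usual scatter of repeated measurements, so the three compounds cannot be told apart on these data.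

The two single-point changes measured so far were both small: a 1.0-fold higher number from compound 1 to compound 2 (0.01 log units; within the scatter) and a 1.2-fold lower number from compound 1 to compound 3 (0.08 log units; within the scatter). In each case the group hanging from the ring nitrogen of the core was exchanged without a shift beyond the scatter.

Compound 4 `COc1cc(/C=C/C(C)=O)ccc1OCc1cn(-c2ccc(C=O)cc2)nn1` is not yet measured. It differs from compound 3 by 4-formylphenyl in place of 2-chlorophenyl on an aromatic nitrogen. This is again a swap of the group on that ring nitrogen, the same kind of change as the two measured steps, which changed nothing beyond the scatter. On that basis the expected step is a 1.1-fold higher number from compound 3 to compound 4 (0.03 log units; within the scatter), that is, no change in this assay that rises above the scatter. Compound 4 is therefore estimated at 52000 nM, with a likely range from 24000 nM to 115000 nM.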

Compound 4, half-maximal inhibitory concentration: 80700 nM
Estimate against measurement, compound 4: 1.6-fold (0.19 log units) below; low and high end bracket the measured number.
By their numbers in this assay, from the lowest: compounds 3, 1, 2 and 4 (each within the scatter of the next).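

In this assay, within the data shown here, placing 4-formylphenyl instead of 2-chlorophenyl on this aromatic nitrogen gives a 1.7-fold higher number from compound 3 to compound 4 (0.23 log units; within the scatter) and is the largest step seen at this position so far, yet it still does not separate the two compounds. The two comparisons made on the same phenyl ring point the same way: formyl in place of methyl on an aromatic carbon gives a 1.4-fold higher number from compound 1 to compound 4 (0.14 log units; within the scatter) and hydrogen in place of ethoxy on a carbonyl carbon gives a 1.4-fold higher number from compound 2 to compound 4 (0.13 log units; within the scatter). The four groups on this nitrogen therefore cannot be told apart on these data, and no other measurement is available to account for the small differences between them.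

The phenyl rings shown carry only methyl, ethoxycarbonyl, chlorine or formyl, so it stays open whether an amine or a carboxylic acid on that ring, or a longer alkyl chain in place of the ring, would give a number beyond the scatter. The methoxy group and the unsaturated ketone chain are the same in all four compounds, so the effect of changing either cannot be read from them.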